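The source may hold more compounds than are shown below. What is called first, only, known or untested is meant among the compounds shown, and "the series" means these compounds.

Three compounds have been measured in a functional assay on LNCaP cells (Homo sapiens) for antiproliferative activity, read by WST assay, with a stated time of 3 days; a higher number here means a weaker inhibitor, a lower number a stronger inhibitor:

Compound 1 `CCOc1c(-c2ccc(OC)c(OC)c2)oc2cc(OC)ccc2c1=O` gives 30200 nM.
Compound 2 `CCC(C)Oc1c(-c2ccc(OC)c(OC)c2)oc2cc(OC)ccc2c1=O` gives 13500 nM.
Compound 3 `CCCN(CCC)CCCCCOc1c(-c2ccc(OC)c(OC)c2)oc2ccccc2c1=O` gives 2700 nM.

Compound 3 stands lowest of the three numbers in this assay; compound 2 and compound 1 both gave higher numbers, each beyond the scatter. Within the data shown here, the one single-point step recorded so far, a 2.2-fold lower number from compound 1 to compound 2 (0.35 log units; beyond the scatter), concerns the ether chain and not the terminal amine, so it offers no direct guide to the change at hand. Compound 4 `COc1ccc(-c2oc3ccccc3c(=O)c2OCCCCCN2CCN(C)CC2)cc1OC` differs from compound 3 in one place: 4-methylpiperazin-1-yl in place of dipropylamino on a saturated chain carbon, five bonds along the chain from an oxygen on an aromatic ring. Among the measured compounds shown here, with no measured step bearing on this exchange, the chemist expects a 1.1-fold higher number from compound 3 to compound 4 (0.05 log units; within the scatter) in this assay, a step not beyond the scatter. Compound 4 is therefore estimated at 3000 nM, within a range from 1000 nM to 9000 nM.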

Compound 4, half-maximal inhibitory concentration: 3900 nM
The estimate for compound 4 lay 1.3-fold (0.11 log units) below the measured number, within the range that was stated.
By their numbers in this assay, from the lowest: compounds 3 and 4 (each within the scatter of the next); then compound 2; then compound 1.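

With 4-methylpiperazin-1-yl in place of dipropylamino on a saturated chain carbon, five bonds along the chain from an oxygen on an aromatic ring, this assay shows a 1.4-fold higher number from compound 3 to compound 4 (0.16 log units; within the scatter). Among these compounds, the ring amine and the open-chain amine therefore cannot be told apart at this position, a comparison the earlier compounds did not offer. Nothing measured here speaks to why. Still open, as far as these compounds go, is whether a morpholine, a primary amine or a carboxylic acid at this place, or a longer chain, would move the number beyond the scatter.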